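The compounds below may be only part of what the source reports. "The series", "measured", "known", "first", "only" and "open" are said of these compounds alone.

In a functional assay on MCF7 cells (Homo sapiens) for antiproliferative activity, read by MTT assay, with a stated time of 72 h (on this read-out higher numbers stand for weaker inhibition and lower numbers for stronger inhibition), three compounds with a shared core have been measured so far: compound 1 `COc1cc2c(Nc3ccc(C#N)cc3)ncnc2cc1OCCCN1CCCCC1` gives 35100 nM, compound 2 `COc1cc2c(Nc3ccc(C#N)cc3)ncnc2cc1OCCCN1CCC(C)CC1` gives 43100 nM and compound 3 `CCOC(=O)C1CCN(CCCOc2cc3ncnc(Nc4ccc(C#N)cc4)c3cc2OC)CC1` gives 34900 nM. These numbers all lie within the usual scatter of one another, so compound 2 cannot be told apart from the other two.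

Compound 4 `COc1cc2c(Nc3ccc(C#N)cc3)ncnc2cc1OCCCN1CCC(N2CCCCC2)CC1` differs from compound 2 by one change: piperidin-1-yl in place of methyl on a saturated ring carbon. In words, this is piperidin-1-yl in place of methyl on a saturated ring carbon. Three measured steps involve changes on that carbon: a 1.2-fold higher number from compound 1 to compound 2 (0.09 log units; within the scatter), a 1.0-fold lower number from compound 1 to compound 3 (0.00 log units; within the scatter) and a 1.2-fold lower number from compound 2 to compound 3 (0.09 log units; within the scatter). None of these steps goes beyond the scatter, so no step beyond the scatter is expected in this assay here. Among the compounds with values here, still, no measured compound carries a ring on that carbon, so the expectation remains uncertain and the range is kept wide.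

For compound 4, the estimated value is 33000 nM, with an expected range of 14000 nM to 70000 nM. This estimate means an expected 1.3-fold lower number from compound 2 to compound 4 (0.12 log units; within the scatter).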

Compound 4, half-maximal inhibitory concentration: 19600 nM
Beside the measured number, compound 4's estimate is 1.7-fold (0.23 log units) above it, and the stated range covers the measured number.
By their numbers in this assay, from the lowest: compounds 4, 3, 1 and 2 (each within the scatter of the next, the first and the last beyond it).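

In this assay, within the data shown here, piperidin-1-yl on this saturated ring carbon gives the first step at the position that goes beyond the scatter, a 2.2-fold lower number from compound 2 to compound 4 (0.34 log units; beyond the scatter), though it is a modest one. The result holds only against methyl, since a 1.8-fold lower number from compound 3 to compound 4 (0.25 log units; within the scatter) and a 1.8-fold lower number from compound 1 to compound 4 (0.25 log units; within the scatter) both stay within the scatter, so here piperidin-1-yl cannot be told apart from ethoxycarbonyl or hydrogen. Nothing at hand gives a reason for the step from methyl.

The compounds shown leave open whether the ring or its nitrogen goes with this step, and cyclohexyl, which has the ring without the nitrogen, or an open-chain dimethylamino group, which has the nitrogen without the ring, could separate the two. They also leave open how a carboxylic acid on this carbon would read in this assay.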